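The source may report more compounds than this note shows. Statements on the series, on what has been measured and on what is new or still open speak of the compounds shown alone.

Three compounds have been measured so far:

Compound 1, `CNc1cc(OC)c(C(=O)NCCN(C)Cc2ccccc2)cc1Cl`, with 0.21 mg/kg.
Compound 2, `COc1cc(N(C)C)c(Cl)cc1C(=O)NCCN(C)Cc1ccccc1`, with 0.54 mg/kg.
Compound 3, `CNc1cc(OC)c(C(=O)NC2CCN(Cc3ccccc3)C2)cc1Cl`, with 0.016 mg/kg.

All three were tested in a functional assay on the whole organism with Rattus norvegicus as the target; a lower number here means that less compound is needed, a higher number that more compound is needed for the effect. Compound 1 and compound 2 share a core and differ in one place only: methyl in place of hydrogen on a nitrogen on an aromatic ring. That single change gave a 2.6-fold higher number from compound 1 to compound 2 (0.41 log units; beyond the scatter), so the dimethylamino compound needed more material than the methylamino one.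

Compound 3 carries the methylamino group of compound 1 but differs from it in a larger part of the molecule; the difference between the two cores is not broken down here. In this assay compound 3 gives the lowest number of the three, and its steps to compound 1 and compound 2 both lie beyond the usual scatter.

Compound 4, `COc1cc(N(C)C)c(Cl)cc1C(=O)NC1CCN(Cc2ccccc2)C1`, has not yet been measured. It stands to compound 3 as compound 2 stands to compound 1: methyl in place of hydrogen on a nitrogen on an aromatic ring. The surroundings of the changed nitrogen are described in the same words in both pairs, so this is the same change made on the core of compound 3.

Because the same change gave a 2.6-fold higher number from compound 1 to compound 2 (0.41 log units; beyond the scatter), a step of similar size is expected here, a 2.5-fold higher number from compound 3 to compound 4 (0.40 log units; beyond the scatter), though it rests on a single earlier pair. Compound 4 is therefore estimated at 0.04 mg/kg in this assay, most likely between 0.015 mg/kg and 0.11 mg/kg.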

Compound 4, dose for half-maximal effect: 0.12 mg/kg
Compound 4: middle estimate off by 3.0-fold (0.48 log units), on the low side; measured number outside the range, above it.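

Adding the methyl to the nitrogen on the aromatic ring, which turns methylamino into dimethylamino, gave a 7.5-fold higher number from compound 3 to compound 4 (0.88 log units; beyond the scatter), so in this assay the direction of the change seen on the first core held on the second. Among the compounds shown here, the size of the step did not hold, and the gap between the two steps is larger than repeated measurements alone would be expected to give: the same change on two cores in this assay, a 2.6-fold higher number (0.41 log units; beyond the scatter) from compound 1 to compound 2 and a 7.5-fold higher number (0.88 log units; beyond the scatter) from compound 3 to compound 4, 2.9-fold (0.46 log units) apart, beyond the scatter of two such steps With only two pairs, this shows that in these compounds the same small change can cost different amounts on different cores, but it does not show what in the cores makes the steps differ, nor how large the step would be on any other core.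

The compounds shown leave open what other groups on that nitrogen would do, for instance an ethyl group in place of the added methyl, or a primary amine with no carbon group on the nitrogen at all. They also leave open whether a third core would give a step closer to the smaller or to the larger of these two.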